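Dithiocarbamate triazole series: chloro to methyl swap

The compounds below may be only part of what the source reports. "The series", "measured", "known", "first", "only" and "open" are said of these compounds alone.

Measured so far:
- compound 1, `Fc1ccccc1Cn1cc(CSC(=S)N2CCNCC2)nn1`: 56200 nM
- compound 2, `S=C(SCc1cn(Cc2ccc(Cl)cc2)nn1)N1CCNCC1`: > 128000 nM

In a functional assay on PC-3 cells (Homo sapiens) for inhibition, read by MTT assay, with a stated time of 72 h (on this read-out higher numbers stand for weaker inhibition and lower numbers for stronger inhibition), compound 1 gives 56200 nM. For compound 2 the value in this assay is a limit of the assay and not a number, > 128000 nM; this is the limit of > 128000 nM in this assay, at which 1 of the 2 values shown sits. The one measured step in this assay, an at least 2.2-fold higher number from compound 1 to compound 2 (0.35 log units; beyond the scatter), therefore fixes only a floor on the loss, and compound 2 stands at the weak end of the two numbers shown.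

Compound 3, `Cc1ccc(Cn2cc(CSC(=S)N3CCNCC3)nn2)cc1`, differs from compound 2 in one place: methyl in place of chloro on an aromatic carbon. Within the data shown here, no measured step in this assay swaps one substituent for another on that ring; the only step known, an at least 2.2-fold higher number from compound 1 to compound 2 (0.35 log units; beyond the scatter), moves the halogen and changes its ring position at the same time, so it bears on this change only loosely. Both the group that leaves and the group that enters are single heavy atoms with no donors or acceptors, so no step beyond the scatter is expected in this assay, and the result may again come back as a limit. The step is estimated as a step that the limit leaves unreadable from compound 2 to compound 3. For compound 3 the expected value in this assay is 150000 nM, within 50000 nM to 450000 nM.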

Compound 3, half-maximal inhibitory concentration: 19800 nM
Compound 3: the middle estimate sits 7.6-fold (0.88 log units) above what was measured, and the stated range ends above it.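

In this assay the aromatic carbon para to a large group proves sensitive to which substituent it carries: methyl in place of chloro gives an at least 6.4-fold lower number from compound 2 to compound 3 (0.81 log units; beyond the scatter), so this swap on the 4-substituted ring is not a neutral exchange in the series. The true size of that step stays unreadable at its far end, since compound 2 is a limit and not a number: the limit of > 128000 nM in this assay, at which 1 of the 3 values shown sits.

The 4-methylphenyl group also compares well with the 2-fluorophenyl group, at a 2.8-fold lower number from compound 1 to compound 3 (0.45 log units; beyond the scatter), which makes compound 3 the strongest of the three compounds shown, with its steps to both others beyond the scatter.

The compounds shown leave open whether the gain is specific to methyl or would carry over to a longer chain such as ethyl, or to a methoxy or a trifluoromethyl group on the same aromatic carbon. Among these compounds, they also leave open whether methyl holds this value at another ring position, since the only fluoro compound differs from compound 3 in both the group and its place on the ring.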